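Methoxy in place of trifluoromethyl on the benzyl ring

The compounds below may be only part of what the source reports. "The series", "measured", "known", "first", "only" and "open" are said of these compounds alone.

The measured compounds:
compound 1 `O=S(=O)(NCCNCc1cccc2ccccc12)c1cc(C(F)(F)F)cc(C(F)(F)F)c1` with 22000 nM
compound 2 `O=S(=O)(NCCCNCc1ccc(C(F)(F)F)cc1)c1cc(C(F)(F)F)cc(C(F)(F)F)c1` with 2000 nM
compound 3 `O=S(=O)(NCCCNCc1ccccc1)c1cc(C(F)(F)F)cc(C(F)(F)F)c1` with 13000 nM

In a functional assay on ASPC1 cells (Homo sapiens) for inhibition, read by MTT assay, with a stated time of 72 h (a higher number here means a weaker inhibitor of growth, a lower number a stronger inhibitor of growth), compound 2 gives the lowest number of the three, with compound 3 next and compound 1 furthest away. Within the data shown here, the one single-point step among them runs a 6.5-fold higher number from compound 2 to compound 3 (0.81 log units; beyond the scatter), a change that removes the trifluoromethyl from the benzyl ring altogether. Compound 4 `COc1ccc(CNCCCNS(=O)(=O)c2cc(C(F)(F)F)cc(C(F)(F)F)c2)cc1` is not yet measured; it differs from compound 2 by methoxy in place of trifluoromethyl on an aromatic carbon. Among the measured compounds shown here, the only step that bears on it is the removal of that same group on going from compound 2 to compound 3, which weakened growth inhibition. A methoxy in the same position is neither the trifluoromethyl nor its absence, so the expected outcome lies between the two measured cases, a loss beyond the scatter but smaller than the step to compound 3. Compound 4 is therefore estimated at 8000 nM, with a range from 3000 nM to 25000 nM, an expected step of a 4.0-fold higher number from compound 2 to compound 4 (0.60 log units; beyond the scatter).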

Compound 4, concentration for 50% growth inhibition: 2800 nM
Compound 4: the middle estimate sits 2.9-fold (0.46 log units) above what was measured; measured number outside the range, below it.
By their numbers in this assay, from the lowest: compounds 2 and 4 (each within the scatter of the next); then compounds 3 and 1 (each within the scatter of the next).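

In this assay, methoxy on this aromatic carbon, para to a large group, matches trifluoromethyl, with a 1.4-fold higher number from compound 2 to compound 4 (0.15 log units; within the scatter) as the step, so the stronger growth inhibition seen with compound 2 does not depend on trifluoromethyl alone. Against the unsubstituted benzyl ring, the same methoxy gives a 4.6-fold lower number from compound 3 to compound 4 (0.67 log units; beyond the scatter) as its step, so the 4-methoxybenzyl and 4-(trifluoromethyl)benzyl groups both stand apart from plain benzyl in this assay. The available evidence offers no account of why two such different groups give numbers this close.

The compounds shown leave open whether a fluorine, a nitrile or a hydroxyl on the same carbon would give a similar number. They also leave open whether the 4-methoxybenzyl group would hold its value on a longer chain.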